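The source may report more compounds than this note shows. Statements on the series, on what has been measured and on what is new or still open speak of the compounds shown alone.

Compound 1 `COc1ccc(-c2nc(CN3CCC(C(=O)c4ccc5c(c4)OCCO5)CC3)co2)cc1` — in an ADME assay on HEK293 cells (Homo sapiens) for cytotoxicity, read by MTT assay, with a stated time of 36 h (a higher number here means a weaker inhibitor, a lower number a stronger inhibitor), compound 1 gives > 150 ug/mL, which is a limit of the assay and not a number.
Compound 2 `Cc1ccc(-c2nc(CN3CCC(C(=O)c4ccc5c(c4)OCCO5)CC3)co2)cc1` — in this assay compound 2 gives > 150 ug/mL, again a limit of the assay.

Among the compounds with values here, compound 2 thus stands at the top of what this assay can report, and the only measured step, a step that the two limits leave unreadable from compound 1 to compound 2, is unreadable in size: both of its ends are limits. Within the data shown here, the one piece of evidence on the measured values is the limit of > 150 ug/mL in this assay, at which 2 of the 2 values shown sit, so no direction or size of change has yet been seen.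

The change to compound 3 `O=C(c1ccc2c(c1)OCCO2)C1CCN(Cc2coc(-c3cccnc3)n2)CC1` is pyridin-3-yl in place of 4-methylphenyl on an aromatic carbon. Among the measured compounds shown here, no measured step bears on this change, and the single step that exists, between two limits, gives no size to carry over. Compound 3 is therefore expected to remain at the limit of this assay, with a step of a number no higher from compound 2 to compound 3 (the limit leaves the size open) meaning no change beyond the scatter. The estimate for compound 3 in this assay is 150 ug/mL, with a range from 75 ug/mL to 300 ug/mL.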

Compound 3, half-maximal inhibitory concentration: > 150 ug/mL
Compound 3 ended at the assay's limit; the forecaster's own chance of this, stated with the estimate: 80%; the middle value lies on the limit itself.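

In this assay compound 3 gives > 150 ug/mL, which is a limit of the assay. The steps to compound 3 from compound 1 and from compound 2 cannot be read, and the evidence remains a single one: the limit of > 150 ug/mL in this assay, at which 3 of the 3 values shown sit.

The compounds shown leave open whether 4-methoxyphenyl, 4-methylphenyl and pyridin-3-yl differ at all in this assay.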